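A few compounds are considered here, and "the series" means these few. Any claim that something is new, unique, unknown or untested is made for them only; others in the source may bear on it.

Measured compounds in the series:
- compound 1, `COc1ccc(-n2cc(CN3C(=O)C[C@@H]4CC[C@@]3(C)C4(C)C)nn2)cc1`: 330 nM
- compound 2, `CC1(C)[C@H]2CC[C@]1(C)N(Cc1cn(-c3ccccc3C#N)nn1)C(=O)C2`: 240 nM
- compound 3, `CC1(C)[C@H]2CC[C@]1(C)N(Cc1cn(-c3cccc(Br)c3)nn1)C(=O)C2`: 90 nM

All three numbers come from a functional assay on PANC-1 cells (Homo sapiens) for inhibition, read by MTT assay, with a stated time of 24 h; on this read-out lower numbers stand for stronger inhibition and higher numbers for weaker inhibition. Compound 3 stands lowest of the three; its nearest neighbour is compound 2, with a 2.7-fold lower number from compound 2 to compound 3 (0.43 log units; beyond the scatter), and the furthest is compound 1, with a 3.7-fold lower number from compound 1 to compound 3 (0.56 log units; beyond the scatter). Between compound 1 and compound 2 the gap is small, a 1.4-fold lower number from compound 1 to compound 2 (0.14 log units; within the scatter).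

The unmeasured compound 4, `CC1(C)[C@H]2CC[C@]1(C)N(Cc1cn(-c3ccc(Br)cc3)nn1)C(=O)C2`, keeps the shared core and differs from compound 3 only in the group on the aromatic nitrogen: 4-bromophenyl in place of 3-bromophenyl on an aromatic nitrogen. For the measured compounds named here, no measured step moves the same group from one position on the phenyl ring to another, so the bearing steps are indirect. The steps from compound 1 and compound 2 to compound 3 show that the choice of substituent on this phenyl ring shifts the result beyond the scatter, but in no consistent direction that can be read onto a change of position alone. Compound 4 is therefore expected to lie between the values of compound 3 and compound 1, with a step of a 1.7-fold higher number from compound 3 to compound 4 (0.22 log units; within the scatter), and its estimated result in this assay is 150 nM, with a range from 60 nM to 400 nM.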

Compound 4, half-maximal inhibitory concentration: 200 nM
The estimate for compound 4 lay 1.3-fold (0.12 log units) below the measured number; low and high end bracket the measured number.
By their numbers in this assay, from the lowest: compound 3; then compounds 4, 2 and 1 (each within the scatter of the next).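

In this assay the bromo group's place on the phenyl ring matters on its own: with the same atoms joined differently, there is a 2.2-fold higher number from compound 3 to compound 4 (0.35 log units; beyond the scatter), a step beyond the scatter that favours 3-bromophenyl over 4-bromophenyl within this pair. The 4-bromophenyl group does not separate from the earlier groups, as both a 1.2-fold lower number from compound 2 to compound 4 (0.08 log units; within the scatter) and a 1.7-fold lower number from compound 1 to compound 4 (0.22 log units; within the scatter) lie within the scatter, so compound 3 alone stands apart among the four compounds. No measurement at hand bears on why the two bromophenyl groups differ.

Going by these compounds, whether the same step would appear with another group in place of bromo on the phenyl ring, such as chloro or an amine, remains open. The compounds shown also leave open how far this difference extends beyond the single cell line and read-out used here.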